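Cytotoxicity Limit Held by Three Analogues, One More Expected

This account rests on a few compounds, and the source may have more. Where it says the series, first, only, none or still open, it means among the compounds named here.

Compound 1 `Cc1ccc2nc(Cn3c(=O)n(C4CC4)c4ccncc43)c(CCCCO)n2c1`: in an ADME assay on HEp-2 cells (Homo sapiens) for cytotoxicity, read by CCK-8 assay, with a stated time of 6 days (on this read-out higher numbers stand for lower toxicity in this test and lower numbers for higher toxicity in this test), compound 1 gives > 100000 nM, which is a limit of the assay.
Compound 2 `O=c1n(Cc2nc3cc(F)ccn3c2CCCCO)c2cnccc2n1C1CC1`: in this assay compound 2 gives > 100000 nM, again a limit.
Compound 3 `O=c1n(Cc2nc3cc(Cl)ccn3c2CO)c2cnccc2n1C1CC1`: in this assay compound 3 gives > 100000 nM, also a limit.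

Compound 3 therefore stands where every measured compound stands, at the limit of > 100000 nM in this assay, at which 3 of the 3 values shown sit, with no numbered value to rank it against the others. Compound 4 `NC(=O)CCc1c(Cn2c(=O)n(C3CC3)c3ccncc32)nc2cc(Cl)ccn12` differs from compound 3 by one change: carbamoylmethyl in place of hydroxy on a saturated chain carbon bound to an aromatic carbon. No step between measured compounds is shown, so the expected step from compound 3 to compound 4 in this assay, a step that the limit leaves unreadable from compound 3 to compound 4, is none beyond the scatter, because the only guide is the limit of > 100000 nM in this assay, at which 3 of the 3 values shown sit. Compound 4 is accordingly estimated at 150000 nM, between 50000 nM and 500000 nM, most likely reported again as a limit.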

Compound 4, half-maximal cytotoxic concentration: > 100000 nM
Compound 4 gave a limit, no number (the forecaster's own chance of this, stated with the estimate: 85%); the middle value lies beyond the limit too.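

No step can be read from compound 3 to compound 4, as each gives only a limit of the assay. The compounds shown leave open at what concentration, if any, these four compounds would turn toxic in this assay.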